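This account rests on a few compounds, and the source may have more. Where it says the series, first, only, none or still open, it means among the compounds named here.

Compound 1 `O=c1nc(NCC2CCCCC2)oc2c([N+](=O)[O-])cc(C(F)(F)F)cc12`: 29.7 ug/mL
Compound 2 `O=c1nc(NCc2ccc3c(c2)OCCO3)oc2c([N+](=O)[O-])cc(C(F)(F)F)cc12`: 25.3 ug/mL
Compound 3 `COc1ccc(CNc2nc(=O)c3cc(C(F)(F)F)cc([N+](=O)[O-])c3o2)cc1OC`: 29.2 ug/mL

In an ADME assay on Vero cells (Chlorocebus sabaeus) for cytotoxicity, read by MTT assay, with a stated time of 48 h (a lower number here means a stronger inhibitor, a higher number a weaker inhibitor), compound 1 stands with the highest number of the three, but all three values sit within the scatter of one another: a 1.0-fold lower number from compound 1 to compound 3 (0.01 log units; within the scatter) and a 1.2-fold lower number from compound 1 to compound 2 (0.07 log units; within the scatter). Compound 4 `CN(Cc1ccccc1)c1nc(=O)c2cc(C(F)(F)F)cc([N+](=O)[O-])c2o1` carries benzyl(methyl)amino in place of (cyclohexylmethyl)amino on an aromatic carbon. For the measured compounds named here, the measured steps both replace the cyclohexyl with an aromatic ring and leave the nitrogen substituent otherwise untouched; the step from compound 1 to compound 4 instead alters both the ring and the nitrogen, so it has no direct precedent. Going by the values given here, the series so far shows no movement in this assay beyond the scatter, so none is expected here either: a 1.0-fold higher number from compound 1 to compound 4 (0.00 log units; within the scatter). Compound 4 is estimated at 30 ug/mL, within 18 ug/mL to 50 ug/mL.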

Compound 4, half-maximal inhibitory concentration: 3.84 ug/mL
The estimate for compound 4 lay 7.8-fold (0.89 log units) above the measured number; measured number below the stated range.
By their numbers in this assay, from the lowest: compound 4; then compounds 2, 3 and 1 (each within the scatter of the next).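

In this assay, this position is not flat: a 7.7-fold lower number from compound 1 to compound 4 (0.89 log units; beyond the scatter). Exchanging cyclohexyl for an aromatic ring with the amino hydrogen retained had left compounds 1, 2 and 3 within the scatter of one another, whereas benzyl(methyl)amino also has no hydrogen-bond donor at this aromatic carbon. No measurement available here bears on the cause of this step. The compounds shown leave open whether the nitrogen methyl or the benzyl ring carries the step. Benzylamino and (cyclohexylmethyl)(methyl)amino would separate the two changes.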